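Aryl urea series: nitro to chloro on the aromatic ring

A few compounds are considered here, and "the series" means these few. Any claim that something is new, unique, unknown or untested is made for them only; others in the source may bear on it.

Measured so far:
compound 1 `O=C(Nc1cccc(C(=O)O)c1)N[C@H]1CC[C@H](Oc2ccc(F)cc2)CC1`
compound 2 `O=C(Nc1cccc([N+](=O)[O-])c1)N[C@H]1CC[C@H](Oc2ccc(F)cc2)CC1`

In a functional assay on CRL2813 cells (Homo sapiens) for cytotoxicity, read by sulforhodamine B assay, with a stated time of 5 days (on this read-out higher numbers stand for weaker inhibition and lower numbers for stronger inhibition), compound 1 gives only the limit > 20000 nM. In this assay, within the data shown here, compound 2 gives 6700 nM, the single number in the set. The measured step of an at least 2.9-fold lower number from compound 1 to compound 2 (0.47 log units; beyond the scatter) is the only one available and concerns the same aromatic carbon. Compound 3 `O=C(Nc1cccc(Cl)c1)N[C@H]1CC[C@H](Oc2ccc(F)cc2)CC1` carries the change (chloro in place of nitro on an aromatic carbon). For compound 3 a small step toward a lower number, or none beyond the scatter, is expected: a 1.7-fold lower number from compound 2 to compound 3 (0.22 log units; within the scatter). The estimate for compound 3 is 4000 nM, range 1500 nM to 12000 nM.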

Compound 3, half-maximal inhibitory concentration: 5900 nM
Beside the measured number, compound 3's estimate is 1.5-fold (0.17 log units) below it; measured number inside the range.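

At this aromatic carbon, 3-chlorophenyl and 3-nitrophenyl read alike in this assay (a 1.1-fold lower number from compound 2 to compound 3 (0.06 log units; within the scatter)), although chloro carries no hydrogen-bond acceptors. A second group, chloro, also gives a step away from carboxy (an at least 3.3-fold lower number from compound 1 to compound 3 (0.53 log units; beyond the scatter)), which therefore does not depend on nitro alone.

On these data alone, whether an amine or a methoxy group on this aromatic carbon reads like chloro and nitro stays open. The full size of the step from carboxy also stays open, since compound 1 gives a limit and not a number: the limit of > 20000 nM in this assay, at which 1 of the 3 values shown sits.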